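Dioxolane side-chain trimming on the shared core

The source may report more compounds than this note shows. Statements on the series, on what has been measured and on what is new or still open speak of the compounds shown alone.

Measured compounds in a functional assay on A549 cells (Homo sapiens) for cytotoxicity, read by MTT assay, with a stated time of 72 h; a higher number here means a weaker inhibitor, a lower number a stronger inhibitor:
- compound 1 `CC1(C)O[C@@H](CO)[C@H](Cn2cc(Cn3c4c(c5ccccc53)C(=O)c3c[n+]([O-])c5ccccc5c3C4=O)nn2)O1`: 370 nM
- compound 2 `O=C1c2c[n+]([O-])c3ccccc3c2C(=O)c2[nH]c3ccccc3c21`: 320 nM
- compound 3 `CN1CCN(CCCn2c3c(c4ccccc42)C(=O)c2c[n+]([O-])c4ccccc4c2C3=O)CC1`: 140 nM

Compound 1 carries the highest number of the three; compound 2 sits within the scatter of it, while compound 3 lies beyond it, with a lower number. Among the compounds with values here, the only step so far is a 2.3-fold lower number from compound 2 to compound 3 (0.36 log units; beyond the scatter), which concerns the aromatic nitrogen of the core and not the dioxolane side chain.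

Compound 4 `CC1(C)OC[C@H](Cn2cc(Cn3c4c(c5ccccc53)C(=O)c3c[n+]([O-])c5ccccc5c3C4=O)nn2)O1` is the next entry. The change is hydrogen in place of hydroxymethyl on a saturated ring carbon. Within the data shown here, no measured pair bears on this position: the side-chain step from compound 2 to compound 3 alters a different place and a different kind of group, so it offers no guide to the size or direction here. With nothing in the series touching the dioxolane, the expectation is a number close to that of compound 1, with no step beyond the scatter. The estimate for compound 4 is therefore 350 nM (range 150 nM to 800 nM), meaning an expected step of a 1.1-fold lower number from compound 1 to compound 4 (0.02 log units; within the scatter).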

Compound 4, half-maximal inhibitory concentration: 340 nM
For compound 4 the middle estimate is 1.0-fold (0.01 log units) above the measured one, within the range that was stated.
By their numbers in this assay, from the lowest: compound 3; then compounds 2, 4 and 1 (each within the scatter of the next).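

In this assay, the position now has its first direct reading: hydrogen in place of hydroxymethyl on a saturated ring carbon of the dioxolane gives a 1.1-fold lower number from compound 1 to compound 4 (0.04 log units; within the scatter). The side chain in compound 4 is therefore trimmed by 2 heavy atoms, 1 hydrogen-bond donor and 1 hydrogen-bond acceptor without a step beyond the scatter, so for this pair hydroxymethyl is not required to hold the number at this level. No supporting data bear on the reason for this result.

From the compounds shown here alone, whether an amine, a carboxylic acid or a longer chain on this carbon would move the number remains open, since the pair spans only hydroxymethyl and hydrogen. Also open, going by these compounds, is whether this change would read the same way in cells other than those of this assay.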